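Replacing a Urea Side Chain with a Basic Amide

The source may report more compounds than this note shows. Statements on the series, on what has been measured and on what is new or still open speak of the compounds shown alone.

Compound 1 `CN1Cc2c(N)cccc2C(c2ccc(F)cc2)C1` carries a free amino group on the shared core, and in a functional assay on the whole organism for inhibition of sodium-dependent dopamine transporter (Mus musculus) (on this read-out higher numbers stand for an effect only at larger amounts of compound and lower numbers for an effect already at smaller amounts), compound 1 gives 7.5 mg/kg. Compound 2 `CCNC(=O)Nc1cccc2c1CN(C)CC2c1ccccc1` carries an ethyl urea in the same place. In this assay compound 2 reaches only a limit of the measurement, > 80 mg/kg. Compound 3 `CCCNC(=O)Nc1cccc2c1CN(C)CC2c1ccccc1` carries a propyl urea. In this assay compound 3 likewise reaches only a limit, > 120 mg/kg. Among the measured compounds shown here, the single measured step, a step that the two limits leave unreadable from compound 2 to compound 3, cannot be sized since both values sit at the limit of > 80 mg/kg in this assay, at which 1 of the 3 values shown sits, and (the limit of > 120 mg/kg in this assay, at which 1 of the 3 values shown sits). Compound 3 thus stands at the upper edge of what the assay can report, far from compound 1.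

Compound 4 `CC(C)NCCC(=O)Nc1cccc2c1CN(C)CC2c1ccccc1` differs from compound 3 in one place: 2-(isopropylamino)ethyl in place of propylamino on a carbonyl carbon. This replaces the urea linkage with an amide bearing a basic side chain. For the measured compounds named here, no measured step tells how this assay responds to such a change, so the expected step of an at least 1.3-fold lower number from compound 3 to compound 4 (0.12 log units; that floor lies within the scatter) rests on the position of compound 3 alone. Compound 4 is estimated at 90 mg/kg, within a range from 20 mg/kg to 150 mg/kg, most likely again only a limit.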

Compound 4, dose for half-maximal effect: about 200 mg/kg
Beside the measured number, compound 4's estimate is 2.2-fold (0.35 log units) below it, outside the stated range (above it).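

In this assay, among the compounds shown here, no step to compound 4 can be read from compound 2 or compound 3, whose values are only limits. The compounds shown leave open how far the ureas of compound 2 and compound 3 truly lie from the amide of compound 4.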